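This account rests on a few compounds, and the source may have more. Where it says the series, first, only, none or still open, it means among the compounds named here.

Compound 1 `CC(C)ONC(=N)c1ccc2[nH]c(-c3cccc(-c4ccccc4O)c3O)cc2c1`, 25000 nM; compound 2 `CC(C)(C)ONC(=N)c1ccc2[nH]c(-c3cccc(-c4ccccc4O)c3O)cc2c1`, < 10000 nM; compound 3 `CCOC(=O)NC(=N)c1ccc2[nH]c(-c3cccc(-c4ccccc4O)c3O)cc2c1`, < 10000 nM.

In a physicochemical assay for solubility, in phosphate buffer, at pH 7.4 (on this read-out higher numbers stand for higher solubility and lower numbers for lower solubility), compound 1 gives 25000 nM. Compound 2 reaches only a limit of the assay, < 10000 nM. Compound 3 likewise reaches only a limit, < 10000 nM. Here (the limit of < 10000 nM in this assay, at which 2 of the 3 values shown sit). So compound 3 stands at the bottom of what the assay reports, and an at least 2.5-fold lower number from compound 1 to compound 3 (0.39 log units; beyond the scatter) is itself a bound, while a step that the two limits leave unreadable from compound 2 to compound 3.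

Compound 4 `CC(=O)OC(C)OC(=O)NC(=N)c1ccc2[nH]c(-c3cccc(-c4ccccc4O)c3O)cc2c1` differs from compound 3 by acetoxy in place of hydrogen on a saturated chain carbon bound to an oxygen next to a carbonyl group and a saturated chain carbon. Within the data shown here, no measured step touches this part of the chain, so the two limits alone guide the expectation. Compound 4 is expected to remain near the limit, with a step that the limit leaves unreadable from compound 3 to compound 4 as the estimated step. For compound 4 the estimate is 7000 nM, spanning 2000 nM to 20000 nM.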

Compound 4, solubility: < 10000 nM
Compound 4: no number, only a limit; the forecaster's own chance of this, stated with the estimate: 60%; the middle value is on the limit's open side.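

Acetoxy on this saturated chain carbon bound to an oxygen next to a carbonyl group does not bring a readable number. In this assay compound 4 gives < 10000 nM, which is a limit of the assay and not a number. The one readable comparison is an at least 2.5-fold lower number from compound 1 to compound 4 (0.39 log units; beyond the scatter), itself a bound, and the steps from compound 2 and compound 3 cannot be read, leaving most of the series at the same limit: the limit of < 10000 nM in this assay, at which 3 of the 4 values shown sit.

From the compounds shown here alone, how far acetoxy moves the value underneath this limit stays open. So does whether an amine or a carboxylic acid on the same carbon would give a number above it.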